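The compounds below may be only part of what the source reports. "The series", "measured", "known", "first", "only" and "open" are said of these compounds alone.

Measured so far in an assay on MDA-MB-231 cells for binding affinity to C-X-C chemokine receptor type 4 (Homo sapiens), read by immunofluorescence and microscopy, with stated times of 10 min and 30 min; a lower number here means that less compound is needed, a higher number that more compound is needed for the effect:
- compound 1 `COc1ccc(C(=O)NCc2ccc(CNS(=O)(=O)c3ccccc3)cc2)cc1` gives 1000 nM
- compound 2 `Cc1ccc(S(=O)(=O)NCc2ccc(CNC(=O)c3ccncc3)cc2)cc1` gives 10 nM
- compound 3 `Cc1cccc(C(=O)NCc2ccc(CNS(=O)(=O)c3ccccc3)cc2)c1` gives 1000 nM

Compound 3 stands level with compound 1, and the two together hold the highest number of the three; compound 2 sits far below both. For the measured compounds named here, the only measured step between neighbours, no change at the digits printed from compound 1 to compound 3 (within the scatter), exchanges one carbon-only ring for another on the carbonyl carbon and leaves the number where it was.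

The next compound, compound 4 `O=C(NCc1ccc(CNS(=O)(=O)c2ccccc2)cc1)c1ccncc1`, is reached from compound 3 by a different kind of exchange: pyridin-4-yl in place of 3-methylphenyl on a carbonyl carbon. The step from compound 1 to compound 3 does not cover this, since it brings in no ring nitrogen. What bears on it instead is compound 2, which also carries pyridin-4-yl on a carbonyl carbon and gives 10 nM in this assay, a number far under those of compound 1 and compound 3. On that basis a large fall in the number is expected for compound 4 in this assay. The step from compound 3 to compound 4 is expected to read a 50-fold lower number from compound 3 to compound 4 (1.70 log units; beyond the scatter). Compound 4 is therefore estimated at 20 nM, with a range from 5 nM to 100 nM.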

Compound 4, effective concentration (reported as EC, without a stated level of effect): 10 nM
For compound 4 the middle estimate is 2.0-fold (0.30 log units) above the measured one; low and high end bracket the measured number.
By their numbers in this assay, from the lowest: compounds 2 and 4 (each within the scatter of the next); then compounds 1 and 3 (each within the scatter of the next).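

In this assay, pyridin-4-yl on the carbonyl carbon gives a 100-fold lower number from compound 3 to compound 4 (2.00 log units; beyond the scatter) and, set against the other carbon-only ring, a 100-fold lower number from compound 1 to compound 4 (2.00 log units; beyond the scatter), so this position responds strongly to this ring even though exchanging one carbon-only ring for the other left the number unchanged. With hydrogen in place of methyl on an aromatic carbon of the sulfonyl-bearing ring, the comparison reads no change at the digits printed from compound 2 to compound 4 (within the scatter), which shows that the low number seen with pyridin-4-yl does not depend on that methyl group. No measurement is available to explain why pyridin-4-yl has this effect.

The compounds shown leave open whether the ring nitrogen must sit as it does in pyridin-4-yl, or whether pyridin-3-yl or pyridin-2-yl on the same carbonyl carbon would give a similarly low number. They also leave open how this position would respond to a nitrogen outside the ring, such as a phenyl ring carrying an amine, or to a phenyl ring carrying a carboxylic acid.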